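This account rests on a few compounds, and the source may have more. Where it says the series, first, only, none or still open, it means among the compounds named here.

Measured in a physicochemical assay for solubility; a lower number here means a less soluble compound, a higher number a more soluble compound:
- compound 1 `CNC(=O)c1cc(C(=O)NC)c(=O)n(Cc2ccccc2)c1`: >= 118 ug/mL, a limit of the assay
- compound 2 `CNC(=O)c1cc(C(=O)NC2CC2)cn(Cc2cccc3[nH]ccc23)c1=O`: 78 ug/mL
- compound 3 `CNC(=O)c1cc(C(N)=O)cn(Cc2ccccc2)c1=O`: 71 ug/mL

Compound 2 at 78 ug/mL and compound 3 at 71 ug/mL lie within the scatter of each other. Compound 1 has no number to set beside them, only its limit.

Compound 4 `CNC(=O)c1cc(C(=O)NC2CC2)cn(Cc2cccc3c2CCN3)c1=O` is not yet measured in this assay. It differs from compound 2 as follows: 2,3-dihydro-1H-indol-4-yl in place of 1H-indol-4-yl on a saturated chain carbon bound to an aromatic nitrogen. In words, this is 2,3-dihydro-1H-indol-4-yl in place of 1H-indol-4-yl on a saturated chain carbon bound to an aromatic nitrogen.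

One measured step is available, an at least 1.6-fold lower number from compound 1 to compound 3 (0.22 log units; that floor lies within the scatter), with hydrogen in place of methyl on an amide-type nitrogen. It starts from compound 1, which sits at the limit of >= 118 ug/mL in this assay, at which 1 of the 3 values shown sits. Among the measured compounds shown here, that step lies elsewhere in the structure, and no measured pair tests the present change, so it gives no size or direction to carry over. The expectation therefore stays anchored on compound 2 at 78 ug/mL, with no shift beyond the scatter.

The estimated step is a 1.1-fold higher number from compound 2 to compound 4 (0.04 log units; within the scatter). Compound 4 is expected at 85 ug/mL, with an estimated range of 35 ug/mL to 200 ug/mL.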

Compound 4, solubility: >= 184 ug/mL
Compound 4 was reported as a limit; the forecaster's own chance of this, stated with the estimate: 15%; middle value at least 2.1-fold (0.33 log units) away from the limit.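

In this assay, 2,3-dihydro-1H-indol-4-yl in place of 1H-indol-4-yl on a saturated chain carbon bound to an aromatic nitrogen gives an at least 2.3-fold higher number from compound 2 to compound 4 (0.37 log units; beyond the scatter), whereas the floor of the earlier step on an amide-type nitrogen, an at least 1.6-fold lower number from compound 1 to compound 3 (0.22 log units; that floor lies within the scatter), lies within the scatter. The pair therefore gives the first sign that this read-out responds to a change at this position, where the five-membered ring is non-aromatic in the entering group and aromatic in the leaving one. Compound 4 is reported only as a limit of the assay, so the step is a floor and its full size cannot be read: the limit of >= 184 ug/mL in this assay, at which 1 of the 4 values shown sits.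

On these data alone, this rests on a single pair on one core, so it remains open whether the same change would give a step of similar size alongside the primary amide of compound 3 or the methyl amide of compound 1. As far as these compounds go, it is also open how an open-chain amine or a carboxylic acid at this place would compare with 2,3-dihydro-1H-indol-4-yl, and the pair does not separate the loss of ring aromaticity from any other difference between the two groups.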